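The source may report more compounds than this note shows. Statements on the series, on what has been measured and on what is new or still open speak of the compounds shown alone.

Compound 3 `Cc1cc(NCc2c[nH]cn2)n2nc(C)c(-c3ccccc3)c2n1` holds the lowest of the two numbers returned by a physicochemical assay for solubility, read by HPLC, using the shake flask method, measured as kinetic solubility, with a stated time of 2 h, at pH 7.4; a lower number here means a less soluble compound, a higher number a more soluble compound: in this assay compound 3 gives 14600 nM. Its nearest neighbour, compound 1 `Cc1cc(NCc2cccnc2)n2nc(C)c(-c3ccccc3)c2n1`, gives 110000 nM, and the step between them is a 7.5-fold lower number from compound 1 to compound 3 (0.88 log units; beyond the scatter). Compound 2 `Cc1cc(Nc2ccccn2)n2nc(C)c(-c3ccccc3)c2n1` yields only a limit of the assay, < 5000 nM. The step from that limit to compound 3 reads an at least 2.9-fold higher number from compound 2 to compound 3 (0.46 log units; beyond the scatter).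

Compound 4 `Cc1cc(NCc2ccco2)n2nc(C)c(-c3ccccc3)c2n1` differs from compound 3 in one place: furan-2-yl in place of 1H-imidazol-4-yl on a saturated chain carbon bound to a nitrogen on an aromatic ring. Among the measured compounds shown here, two measured steps bear on it. The exchange of the ring on the same saturated chain carbon, a 7.5-fold lower number from compound 1 to compound 3 (0.88 log units; beyond the scatter), was modest and beyond the scatter; the exchange of the whole group on the ring nitrogen, an at least 2.9-fold higher number from compound 2 to compound 3 (0.46 log units; beyond the scatter), was at least modest. Both show that changing this ring shifts solubility by a clear margin. For compound 4 a modest downward step in this assay is therefore expected, a 2.1-fold lower number from compound 3 to compound 4 (0.32 log units; beyond the scatter). Compound 4 is estimated at 7000 nM, within a range from 2500 nM to 25000 nM.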

Compound 4, solubility: < 5000 nM
Compound 4 ended at the assay's limit; the forecaster's own chance of this, stated with the estimate: 30%; middle value at least 1.4-fold (0.14 log units) from the limit.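

Among the compounds shown here, at this position the ring on the saturated chain carbon carries more weight than the earlier compounds showed: in this assay, furan-2-yl gives an at least 2.9-fold lower number from compound 3 to compound 4 (0.46 log units; beyond the scatter), and against pyridin-3-yl it gives an at least 22-fold lower number from compound 1 to compound 4 (1.34 log units; beyond the scatter). Until now only compound 2, which has no such chain carbon, had reached the limit, whereas compound 4 keeps that carbon, so in this set the chain carbon alone does not hold a compound clear of the limit. The step between compound 2 and compound 4 cannot be read, as both values are limits: the limit of < 5000 nM in this assay, at which 2 of the 4 values shown sit.

From the compounds shown here alone, how far compound 2 and compound 4 lie beyond that limit stays open. Also open, going by these compounds, is how this assay would read with an amine or a carboxylic acid on the ring at this position, or with a longer chain.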